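Amide and urea variants on the shared core, cell tolerance

A few compounds are considered here, and "the series" means these few. Any claim that something is new, unique, unknown or untested is made for them only; others in the source may bear on it.

Measured so far:
compound 1 `COc1cc(-c2nn(-c3cccc(NC(=O)c4cccc(C(F)(F)F)c4)c3)cc2-c2ccncc2)ccc1Cl`: > 50000 nM
compound 2 `COc1cc(-c2nn(-c3cccc(NC(=O)Nc4ccc(Cl)c(Cl)c4)c3)cc2-c2ccncc2)ccc1Cl`: > 50000 nM
compound 3 `COc1cc(-c2nn(-c3cccc(NC(=O)Nc4cccc(C(F)(F)F)c4)c3)cc2-c2ccncc2)ccc1Cl`: > 50000 nM

In a functional assay on 786-0 cells (Homo sapiens) for inhibition, read by sulforhodamine B assay, with a stated time of 48 h (a higher number here means that more compound is tolerated, a lower number that less compound is tolerated), compound 1 gives > 50000 nM, which is a limit of the assay and not a number. Compound 2 likewise reaches only a limit in this assay, at > 50000 nM. Compound 3 stands at a limit as well, > 50000 nM, so its place among the three can be told only as far as the limit of > 50000 nM in this assay, at which 3 of the 3 values shown sit, allows: all three sit at the same limit, and none is separated from another.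

The steps among them are therefore unreadable: a step that the two limits leave unreadable from compound 1 to compound 2, a step that the two limits leave unreadable from compound 1 to compound 3 and a step that the two limits leave unreadable from compound 2 to compound 3 cannot be given a size.

Compound 4 `COc1cc(-c2nn(-c3cccc(NC(=O)c4ccc(Cl)c(C(F)(F)F)c4)c3)cc2-c2ccncc2)ccc1Cl` differs from compound 3 by 4-chloro-3-(trifluoromethyl)phenyl in place of (3-(trifluoromethyl)phenyl)amino on a carbonyl carbon. The change from compound 1 to compound 3 concerns the same carbonyl carbon, and from compound 1 to compound 2 the aryl pattern is changed, yet both steps leave no readable size. Within the data shown here, no measured step bears a number on which to build, so the expectation for compound 4 rests on the limit alone. Compound 4 is expected to tolerate roughly 60000 nM (range 10000 nM to 300000 nM), most probably again reported only as a limit. The step from compound 3 to compound 4 is therefore estimated as a step that the limit leaves unreadable from compound 3 to compound 4, not beyond the scatter.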

Compound 4, concentration lethal to 50% of the cells: > 32500 nM
Compound 4 gave a limit, no number; the forecaster's own chance of this, stated with the estimate: 80%; the middle value is on the limit's open side.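

In this assay compound 4 gives > 32500 nM, a limit of the assay and not a number. Among these compounds, all four values are limits, so no step from compound 1, compound 2 or compound 3 to compound 4 can be read. The compounds shown leave open how these amide and urea variants rank in this assay.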